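Fluoro removed from the aryl ring: outlook for compound 4

The compounds below may be only part of what the source reports. "The series", "measured", "known", "first", "only" and "open" are said of these compounds alone.

Measured so far in an assay on cell membranes for displacement of a labelled ligand from Adrenergic receptor alpha-1 (Rattus norvegicus); on this read-out lower numbers stand for stronger inhibition and higher numbers for weaker inhibition:
- compound 1 `Cc1ccc2c(C3CCN(CCN4CCN(C(C)C)C4=O)CC3)cn(-c3ccc(F)cc3)c2c1`: 85 nM
- compound 2 `CC(C)N1CCN(CCN2CCC(c3cn(-c4ccc(F)cc4)c4cc(F)ccc34)CC2)C1=O`: 13 nM
- compound 3 `CC(C)c1ccc2c(C3CCN(CCN4CCN(C(C)C)C4=O)CC3)cn(-c3ccc(F)cc3)c2c1`: 730 nM

Compound 1 stands second highest of the three numbers in this assay; the steps of a 6.5-fold lower number from compound 1 to compound 2 (0.82 log units; beyond the scatter) and an 8.6-fold higher number from compound 1 to compound 3 (0.93 log units; beyond the scatter) both lie beyond the scatter, and the pair a 56-fold higher number from compound 2 to compound 3 (1.75 log units; beyond the scatter) is large.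

Compound 4 `Cc1ccc2c(C3CCN(CCN4CCN(C(C)C)C4=O)CC3)cn(-c3ccccc3)c2c1` differs from compound 1 by hydrogen in place of fluoro on an aromatic carbon, read one bond further out as 4-fluorophenyl to phenyl. Going by the values given here, no measured step touches this ring: all three steps vary the group on the other six-membered aromatic ring of the shared core. With no direct guide, the expected step of a 1.4-fold higher number from compound 1 to compound 4 (0.15 log units; within the scatter) is small, probably within the scatter, with a slight lean towards a weaker number. Compound 4 is therefore estimated at 120 nM in this assay, within 45 nM to 320 nM.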

Compound 4, half-maximal inhibitory concentration: 120 nM
Compound 4: middle estimate and measured number agree at the digits printed; low and high end bracket the measured number.
By their numbers in this assay, from the lowest: compound 2; then compounds 1 and 4 (each within the scatter of the next); then compound 3.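

In this assay, going by these compounds alone, the step of a 1.4-fold higher number from compound 1 to compound 4 (0.15 log units; within the scatter) is the first reading at the 4-fluorophenyl group, and it stays within the scatter. On this background, fluoro on this ring can give way to hydrogen with no readable change, whereas every earlier step, all on the other six-membered aromatic ring, lay beyond the scatter. No measurement at hand bears on the reason for this difference. Open, on these data alone, is whether a larger group at this place, such as methoxy or a carboxylic acid, would leave the number equally unmoved. The one exchange shown covers only fluoro and hydrogen, and only with the methyl group of compound 1 on the core.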